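Swapping the aryl group on a saturated ring carbon

The source may hold more compounds than are shown below. What is called first, only, known or untested is meant among the compounds shown, and "the series" means these compounds.

Of the compounds shown here, three have been measured in a functional assay on BGC-823 cells (Homo sapiens) for antiproliferative activity, read by MTT assay, tested at 5 uM; a lower number here means a weaker effect, a higher number a stronger effect of the compound at the concentration tested. Compound 1 `COc1cc(C(=O)N/N=C/c2ccc(F)c(F)c2)cc(OC)c1OC` gives 51.9%. Compound 3 `COc1cc(C(=O)N/N=C/c2cccc(C(F)(F)F)c2)cc(OC)c1OC` gives 33.8%. Compound 2 `COc1cc(C2=NN(C(C)=O)C(c3cc(Cl)cc(Cl)c3)O2)cc(OC)c1OC` gives 6.6%, the lowest of the three numbers; its nearest neighbour is compound 3, and the gap to it, like the larger gap to compound 1, lies beyond the usual scatter. Among the measured compounds shown here, none of these three pairs differs in only one place, so no single-change step among the measured compounds is available.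

Compound 4 `COc1cc(C2=NN(C(C)=O)C(c3ccc(F)cc3)O2)cc(OC)c1OC` is not yet measured. It differs from compound 2 as follows: 4-fluorophenyl in place of 3,5-dichlorophenyl on a saturated ring carbon. For the measured compounds named here, since no measured pair shows the effect of a change of this kind on the shared core of compound 2, the expectation for this assay rests on compound 2 alone. The step from compound 2 to compound 4 is expected to be small, a number 5.4 percentage points higher from compound 2 to compound 4 (within the scatter), and to lie within the scatter. Compound 4 is therefore estimated at 12%, with a range from 0% to 30%.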

Compound 4, a percentage reported as inhibition, at one concentration (the size of the read-out at that concentration, not a potency): 13.3%
For compound 4 the middle estimate is 1.3 percentage points below the measured one; the measured number falls inside the stated range.
By their numbers in this assay, from the lowest: compounds 2 and 4 (each within the scatter of the next); then compound 3; then compound 1.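

In this assay, the first step available on this core is a number 6.7 percentage points higher from compound 2 to compound 4 (within the scatter), with 4-fluorophenyl in place of 3,5-dichlorophenyl on the saturated ring carbon. At this position, then, exchanging one of these halogen-bearing phenyl groups for the other does not move the read-out beyond the usual scatter at the concentration tested. Nothing measured here bears on the reason for this result.

The compounds shown leave open whether a group of another kind on this ring carbon, such as a phenyl ring carrying an amine or a carboxylic acid, or a longer chain in place of the ring, would shift the number beyond the scatter. They also leave open what would follow if a longer chain took the place of the acetyl group.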